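The source may report more compounds than this note shows. Statements on the series, on what has been measured and on what is new or still open speak of the compounds shown alone.

Notes on the series. Compound 1 `CCN(CC)Cc1ccc2nc(NC(=O)N/N=C/c3cn(Cc4ccc(C(C)(C)C)cc4)c4ccccc34)sc2c1` in a functional assay on A549 cells (Homo sapiens) for cytotoxicity, read by MTT assay, with a stated time of 72 h (on this read-out lower numbers stand for stronger inhibition and higher numbers for weaker inhibition), gives 1710 nM. Compound 2 `CC1CCN(Cc2ccc3nc(NC(=O)N/N=C/c4cn(Cc5ccc(C(C)(C)C)cc5)c5ccccc45)sc3c2)CC1` in this assay gives 3710 nM. Among the compounds with values here, the one measured step, a 2.2-fold higher number from compound 1 to compound 2 (0.34 log units; beyond the scatter), concerns a change on the saturated chain carbon bound to an aromatic carbon. On the numbers at hand compound 1 stands lowest of the two, with compound 2 the nearest by that step.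

Compound 3 `CCN(CC)Cc1ccc2nc(NC(=O)N/N=C/c3cn(Cc4ccc(Cl)c(Cl)c4)c4ccccc34)sc2c1` keeps the diethylamino of compound 1 and changes the other end of the shared core: 3,4-dichlorophenyl in place of 4-(tert-butyl)phenyl on a saturated chain carbon bound to an aromatic nitrogen. Within the data shown here, no measured step touches this place; the step from compound 1 to compound 2 sits elsewhere and tells nothing of what a 3,4-dichlorophenyl does where a 4-(tert-butyl)phenyl stood. Among the measured compounds shown here, with no precedent for a change at this place, the expectation for compound 3 is a step of about a 1.2-fold higher number from compound 1 to compound 3 (0.07 log units; within the scatter), held close to no change and given a wide width. Compound 3 is expected at 2000 nM in this assay, within 700 nM to 6000 nM.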

Compound 3, half-maximal inhibitory concentration: 1470 nM
For compound 3 the middle estimate is 1.4-fold (0.13 log units) above the measured one; low and high end bracket the measured number.
By their numbers in this assay, from the lowest: compounds 3 and 1 (each within the scatter of the next); then compound 2.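

Within the data shown here, at the saturated chain carbon bound to an aromatic nitrogen, 3,4-dichlorophenyl in place of 4-(tert-butyl)phenyl gives a 1.2-fold lower number from compound 1 to compound 3 (0.07 log units; within the scatter) in this assay and so provides the first measured change at this end of the shared core. With the diethylamino held fixed, the exchange of 10 heavy atoms, all carbon, for 8 heavy atoms, 6 of them carbon and 2 chlorine, produces no difference beyond the scatter, so this read-out does not separate the two groups. Nothing available explains this result.

The compounds shown leave open whether the step to 4-methylpiperidin-1-yl carries over to the 3,4-dichlorobenzyl series, since that amine appears here only with 4-(tert-butyl)benzyl. They also leave open whether the indifference seen at this place extends beyond these two lipid-free carbon and chlorine substituted rings, for instance to a phenyl ring bearing a carboxylic acid or a dimethylamino group, or to a longer chain between the ring and the aromatic nitrogen.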